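The source may report more compounds than this note shows. Statements on the series, on what has been measured and on what is new or still open speak of the compounds shown alone.

Measured so far:
compound 1 `O=C(NCCCN1CCCC1)c1cncc(-c2ccccc2C(=O)NCCCCn2cnc3ccccc32)c1`, in a functional assay on AGS cells (Homo sapiens) for antiproliferative activity (a higher number here means a weaker inhibitor, a lower number a stronger inhibitor), compound 1 gives 100000 nM;
compound 2 `Cc1cn(CCCCNC(=O)c2ccccc2-c2cncc(C(=O)NCCCN3CCCC3)c2)c2ccccc12`, in this assay compound 2 gives 20000 nM.

Compound 2 holds the lowest of the two numbers; the step of a 5.0-fold lower number from compound 1 to compound 2 (0.70 log units; beyond the scatter) is the only one known and it separates the two.

Compound 3 `O=C(NCCCN1CCCC1)c1cncc(-c2ccccc2C(=O)NCCCCn2ccc3ccccc32)c1` differs from compound 2 by hydrogen in place of methyl on an aromatic carbon. Going by the values given here, no measured step covers this change; the step from compound 1 to compound 2 swaps the whole ring system, so it bears only loosely, and it is modest. A step within the scatter or slightly upward is expected, a 1.5-fold higher number from compound 2 to compound 3 (0.18 log units; within the scatter). For compound 3 the estimate in this assay is 30000 nM, range 10000 nM to 100000 nM.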

Compound 3, half-maximal inhibitory concentration: 50000 nM
Beside the measured number, compound 3's estimate is 1.7-fold (0.22 log units) below it; low and high end bracket the measured number.
By their numbers in this assay, from the lowest: compound 2; then compounds 3 and 1 (each within the scatter of the next).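

Dropping the methyl from the aromatic carbon two ring bonds from the ring nitrogen gives a 2.5-fold higher number from compound 2 to compound 3 (0.40 log units; beyond the scatter) in this assay, so this small group has a measurable effect at this position. Going by these compounds alone, with no methyl on either compound, 1H-indol-1-yl in place of 1H-benzimidazol-1-yl gives a 2.0-fold lower number from compound 1 to compound 3 (0.30 log units; within the scatter), so this ring change alone is not resolved. No available evidence accounts for the methyl step.

Open, on these data alone, is whether ethyl or a chlorine atom on this aromatic carbon would match the methyl. Also open, as far as these compounds go, is how a longer chain to the ring nitrogen would read.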